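The source may report more compounds than this note shows. Statements on the series, on what has been measured and on what is new or still open speak of the compounds shown alone.

Measured in an assay on CHO cells, read by calcium flux (a lower number here means a stronger inhibitor, a higher number a weaker inhibitor), so far:
compound 1, `O=C(Nc1ccc(C(F)(F)F)cc1)c1csc(Oc2c(Cl)cccc2Cl)n1`, 1280 nM
compound 2, `O=C(Nc1ccc(C(F)(F)F)cc1)c1csc(Nc2c(Cl)cccc2Cl)n1`, 48 nM

Among the measured compounds shown here, compound 2 holds the lower of the two numbers in this assay; its only neighbour is compound 1, and the step between them is large: a 27-fold lower number from compound 1 to compound 2 (1.43 log units; beyond the scatter). That step exchanges the link between the shared core and the 2,6-dichlorophenyl ring and leaves the substituents on that ring untouched.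

Compound 3, `O=C(Nc1ccc(C(F)(F)F)cc1)c1csc(Nc2c(Cl)cccc2C(F)(F)F)n1`, has not yet been measured in this assay. It differs from compound 2 as follows: trifluoromethyl in place of chloro on an aromatic carbon. For the measured compounds named here, no measured pair varies a substituent on this ring, so the one step on record, a 27-fold lower number from compound 1 to compound 2 (1.43 log units; beyond the scatter), does not bear on the change from compound 2 to compound 3; neither its direction nor its size can be read from the measured compounds. With nothing to point either way, the working assumption is a step within the scatter, held with a wide range. Compound 3 is therefore expected to give about 60 nM in this assay, between 18 nM and 220 nM, which corresponds to an expected 1.3-fold higher number from compound 2 to compound 3 (0.10 log units; within the scatter).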

Compound 3, half-maximal inhibitory concentration: > 4000 nM
Compound 3 ended at the assay's limit; the forecaster's own chance of this, stated with the estimate: 2%; middle value at least 66-fold (1.82 log units) away from the limit.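

For compound 3 the reading in this assay is a limit of the assay and not a number: the limit of > 4000 nM in this assay, at which 1 of the 3 values shown sits. Among the compounds shown here, this is the first measured change to a substituent on the 2,6-dichlorophenyl ring, and trifluoromethyl in place of chloro gives an at least 83-fold higher number from compound 2 to compound 3 (1.92 log units; beyond the scatter), so the substituent at this position is far from indifferent to the read-out. The amino link stays the same across this pair, which shows that the number in this assay depends on the ring substituent as well as on the link, the only feature varied before in a 27-fold lower number from compound 1 to compound 2 (1.43 log units; beyond the scatter).

From the compounds shown here alone, with only chloro and trifluoromethyl compared at this position, it remains open how a fluoro, a methyl or a methoxy group would read there, and thus which feature of trifluoromethyl accounts for the step. Also open, going by these compounds, are the full size of the step, which the limit leaves unread, and whether the same exchange would have a comparable outcome with the oxygen link of compound 1.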